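The source may report more compounds than this note shows. Statements on the series, on what has been measured and on what is new or still open speak of the compounds shown alone.

Measured compounds:
compound 1 `O=C(Nc1cccc(-n2cc(-c3ccncc3)c(-c3cc(O)cc(Cl)c3)n2)c1)Nc1ccc(Cl)c(C(F)(F)F)c1` gives 41.5%
compound 2 `O=C(Nc1cccc(-n2cc(-c3ccncc3)c(-c3cc(O)cc(Cl)c3)n2)c1)Nc1ccc(Cl)c(Cl)c1` gives 12.8%
compound 3 `COc1cc(Cl)cc(-c2nn(-c3cccc(NC(=O)Nc4cc(C(F)(F)F)cc(C(F)(F)F)c4)c3)cc2-c2ccncc2)c1` gives 2.37%

All three were tested in a functional assay on NCI/ADR-RES cells (Homo sapiens) for inhibition, read by sulforhodamine B assay, with a stated time of 48 h, tested at 10 uM; on this read-out higher numbers stand for a weaker effect at the one concentration tested and lower numbers for a stronger effect. Among these numbers compound 2 stands second highest: compound 1 lies higher and compound 3 lower, both beyond the scatter. Among the measured compounds shown here, the only step measured between two compounds differing in one place is a number 28.7 percentage points lower from compound 1 to compound 2 (beyond the scatter), a change on the urea side of the shared core.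

Compound 4 `COc1cc(Cl)cc(-c2nn(-c3cccc(NC(=O)Nc4ccc(Cl)c(Cl)c4)c3)cc2-c2ccncc2)c1` differs from compound 2 in one place: methyl in place of hydrogen on an oxygen on an aromatic ring. For the measured compounds named here, no measured pair differs by this change alone, so no step bears on it directly. Going by the values given here, compound 3 carries the methoxy that compound 4 gains, but it also differs from compound 2 on the urea side, so its value shows only that a methoxy-bearing compound can give a low number in this assay. Among the compounds with values here, with no direct precedent, no change beyond the scatter is expected in this assay. The expected step is a number 2.8 percentage points lower from compound 2 to compound 4 (within the scatter). Compound 4 is therefore estimated at 10%, within 1% to 30%.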

Compound 4, a percentage reported as activity, at one concentration (the size of the read-out at that concentration, not a potency): 8.59%
Compound 4: middle estimate off by 1.4 percentage points, on the high side; the range from low to high includes it.
By their numbers in this assay, from the lowest: compounds 3, 4 and 2 (each within the scatter of the next, the first and the last beyond it); then compound 1.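

Turning hydroxy into methoxy on the 3-chloro-5-hydroxyphenyl group gives a number 4.2 percentage points lower from compound 2 to compound 4 (within the scatter) in this assay, and this is the first step in the series measured at this position rather than on the urea side. At this one concentration and with this urea side, the hydrogen on that oxygen can therefore be replaced by methyl without a change beyond the usual scatter, so a free hydroxy is not required for a low number here. The data offer no measurement that could explain why the two compounds read alike.

As far as these compounds go, it remains open whether a longer chain on that oxygen, such as ethyl, or an amine in place of the hydroxy would read the same. From the compounds shown here alone, it is also open whether this swap would behave the same way with the urea side of compound 1.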